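This account rests on a few compounds, and the source may have more. Where it says the series, first, only, none or still open, it means among the compounds named here.

Compound 1 `COc1ccccc1C1CC(c2cc3ccccc3o2)=NN1C(=O)c1ccncc1`. In an ADME assay on Vero cells (Chlorocebus sabaeus) for cytotoxicity, read by MTT assay, with a stated time of 72 h (a lower number here means a stronger inhibitor, a higher number a weaker inhibitor), compound 1 gives only a limit, > 202000 nM.
Compound 2 `COc1ccc(C2CC(c3cc4ccccc4o3)=NN2C(=O)c2ccncc2)cc1`. In this assay compound 2 likewise gives only a limit, > 200000 nM.
Compound 3 `CCn1cc(C(=O)N2N=C(c3cc4ccccc4o3)CC2c2ccccc2O)c(=O)c2ccc(C)nc21`. In this assay compound 3 also gives only a limit, > 157000 nM.

Compound 3 therefore stands on a limit, not on a number, and the same holds for the other two values shown: one sits at the limit of > 157000 nM in this assay, at which 1 of the 3 values shown sits, one at the limit of > 200000 nM in this assay, at which 1 of the 3 values shown sits, and one at the limit of > 202000 nM in this assay, at which 1 of the 3 values shown sits. None of the three compounds shows measurable cytotoxicity within the tested range.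

Compound 4 `CCn1cc(C(=O)N2N=C(c3cc4ccccc4o3)CC2c2ccc(N(C)C)cc2)c(=O)c2ccc(C)nc21` differs from compound 3 in one place: 4-(dimethylamino)phenyl in place of 2-hydroxyphenyl on a saturated ring carbon.

Among the measured compounds shown here, only one measured step exists among the compounds, a step that the two limits leave unreadable from compound 1 to compound 2, and it cannot be read because both ends are limits. For the measured compounds named here, no measured step therefore bears on the change from the 2-hydroxyphenyl group to the 4-(dimethylamino)phenyl group, and no shift beyond the scatter in this assay can be argued for from the data.

Compound 4 is accordingly expected to remain at or near the limit, with an estimate of 160000 nM and a range from 50000 nM to 500000 nM. This corresponds to an expected step that the limit leaves unreadable from compound 3 to compound 4.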

Compound 4, half-maximal inhibitory concentration: > 206000 nM
Compound 4: a limit, no number; the forecaster's own chance of this, stated with the estimate: 75%; middle value at least 1.2-fold (0.10 log units) from the limit.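

Compound 3 and compound 4 both give only limits in this assay, not numbers, so the step from one to the other cannot be read. The compounds shown leave open at what concentration, if any, each would become toxic to these cells, and whether swapping these groups changes that.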